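Acetamido in place of methylsulfanyl: expectation before measurement

A few compounds are considered here, and "the series" means these few. Any claim that something is new, unique, unknown or untested is made for them only; others in the source may bear on it.

Of the compounds shown here, two have numbers so far. Compound 1 `CC(C)(C)c1ccc(C(=O)NCc2ccc(N)cc2Cl)cc1` gives 46 nM in an assay on HeLa cells with Bile acid receptor (Homo sapiens) as the target, read by a luciferase reporter, with a stated time of 24 h; on this read-out lower numbers stand for an effect already at smaller amounts and higher numbers for an effect only at larger amounts of compound. Compound 2 `CSc1ccc(CNC(=O)c2ccc(C(C)(C)C)cc2)cc1` gives 100 nM in this assay, the highest of the two numbers; its nearest neighbour is compound 1, whose number lies lower by a margin beyond the scatter. Within the data shown here, compounds 1 and 2 differ in more than one place, so no single step is drawn between them, and only their two values are on record.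

Compound 3 `CC(=O)Nc1ccc(CNC(=O)c2ccc(C(C)(C)C)cc2)cc1` is the next compound, not yet measured. It keeps the shared core of compound 2 and changes one group: acetamido in place of methylsulfanyl on an aromatic carbon. Among the measured compounds shown here, nothing in the measured pair isolates this exchange, and no step between measured compounds carries a comparable swap, so the direction of the change cannot be read from the numbers at hand. A step of modest size is expected in this assay, with the outcome uncertain in either direction, and the step from compound 2 is estimated as a 1.4-fold lower number from compound 2 to compound 3 (0.15 log units; within the scatter). For compound 3 the expected value in this assay is 70 nM, within a range of 25 nM to 250 nM.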

Compound 3, half-maximal effective concentration: 2900 nM
The estimate for compound 3 lay 41-fold (1.62 log units) below the measured number; the whole stated range lies below it.
By their numbers in this assay, from the lowest: compound 1; then compound 2; then compound 3.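

In this assay, the aromatic carbon para to a large group proves sensitive to the identity of its substituent: acetamido in place of methylsulfanyl gives a 29-fold higher number from compound 2 to compound 3 (1.46 log units; beyond the scatter), a large step that the earlier pair could not have shown, since those two compounds differ in more than one place. The entering acetamido has 4 heavy atoms and 1 hydrogen-bond donor, against 2 heavy atoms and 0 hydrogen-bond donors for methylsulfanyl, so size and donor count change together in this one exchange and the step cannot separate them. Nothing available bears on the reason for the step.

The compounds shown leave open whether a group of similar size without the amide hydrogen, such as an acetyl or a methoxymethyl group, or an acetamido carrying a methyl on its nitrogen, would stay close to compound 2 or follow compound 3. Going by these compounds, it also remains open whether the same exchange would give a step of similar size on the core of compound 1, which carries a chlorine.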